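Benzylamino for Nitro on an Imidazopyrimidine Scaffold

A few compounds are considered here, and "the series" means these few. Any claim that something is new, unique, unknown or untested is made for them only; others in the source may bear on it.

Measured compounds:
- compound 1, `CC(=O)Nc1cc(OCC(C)C)nc(SCc2ccccc2)n1`, 64400 nM
- compound 2, `CC(=O)Nc1cc(=O)n(Cc2ccccc2)c(SCc2ccccc2)n1`, 71700 nM
- compound 3, `COc1cc(OC)n2cc(-c3ccc([N+](=O)[O-])cc3)nc2n1`, 35900 nM

All three compounds were tested in a functional assay on HepG2 cells (Homo sapiens) for antiproliferative activity, read by MTT assay, with a stated time of 72 h; on this read-out lower numbers stand for stronger inhibition of growth and higher numbers for weaker inhibition of growth. Compound 1 gives 64400 nM, compound 2 gives 71700 nM, and compound 3 gives 35900 nM. Compound 3 carries the lowest of the three numbers, but its gap to compound 1 and its gap to compound 2 both lie within the usual scatter of this assay, so the three compounds cannot be separated from one another on these data, and no ranking among them is supported.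

Compound 4, `COc1cc(OC)n2cc(-c3ccc(NCc4ccccc4)cc3)nc2n1`, has not yet been measured. It differs from compound 3 in one place: benzylamino in place of nitro on an aromatic carbon. Going by the values given here, no step between two measured compounds involves this exchange, so there is nothing in the measured set that points to a direction for this change. The expectation for compound 4 therefore rests on compound 3 alone, whose value of 35900 nM serves as the anchor. Compound 4 is estimated at 30000 nM in this assay, with a range from 8000 nM to 120000 nM. The step expected from compound 3 to compound 4 is a 1.2-fold lower number from compound 3 to compound 4 (0.08 log units; within the scatter), which is no more than the scatter of repeated measurements.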

Compound 4, concentration for 50% growth inhibition: > 100000 nM
Compound 4: a limit, no number; the forecaster's own chance of this, stated with the estimate: 15%; middle value at least 3.3-fold (0.52 log units) from the limit.
By their numbers in this assay, from the lowest: compounds 3, 1 and 2 (each within the scatter of the next). At a limit, above all of these: compound 4.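

In this assay compound 4 gives > 100000 nM, which is a limit of the assay and not a number. Benzylamino in place of nitro on this aromatic carbon, para to a large group, gives an at least 2.7-fold higher number from compound 3 to compound 4 (0.44 log units; beyond the scatter), the only step among the compounds shown and one that stands beyond the scatter, so this position does not tolerate the change without a weaker inhibition of growth, something that the three earlier compounds, which could not be separated from one another, gave no sign of. The full size of this step stays unknown because compound 4 stands at a limit of the assay: the limit of > 100000 nM in this assay, at which 1 of the 4 values shown sits.

As far as these compounds go, whether a plain amine or a methylamino group on this same carbon would read like compound 3 or like compound 4 stays open, and such a comparison would separate the part played by the nitrogen from that of the added benzyl ring. Also open, from the compounds shown here alone, is how a nitrile or a carboxylic acid in place of nitro would read, so the change from compound 3 rests on this single exchange.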